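A few compounds are considered here, and "the series" means these few. Any claim that something is new, unique, unknown or untested is made for them only; others in the source may bear on it.

Within the data shown here, in a functional assay on SK-BR-3 cells (Homo sapiens) for cytotoxicity, read by MTT assay, with a stated time of 72 h (a higher number here means a weaker inhibitor, a lower number a stronger inhibitor), compound 1 `O=C(NCc1ccc(F)cc1)c1nc(Br)c2cccnc2c1N1CCNCC1` gives 6000 nM and compound 2 `COC(=O)CNc1c(C(=O)NCc2ccc(F)cc2)nc(Br)c2cccnc12` gives 1000 nM, the lower of the two numbers so far. Among the measured compounds shown here, the single measured step, a 6.0-fold lower number from compound 1 to compound 2 (0.78 log units; beyond the scatter), is modest and places ((methoxycarbonyl)methyl)amino where piperazin-1-yl stood on an aromatic carbon. Compound 3 `NCCCCCCNc1c(C(=O)NCc2ccc(F)cc2)nc(Br)c2cccnc12` alters the chain of compound 2: 5-aminopentyl in place of methoxycarbonyl on a saturated chain carbon bound to a nitrogen on an aromatic ring. The result is (6-aminohexyl)amino in place of ((methoxycarbonyl)methyl)amino. For the measured compounds named here, that measured step is the only one bearing on this change, and it bears only indirectly: neither of its compounds carries the new chain, and the data set no direction. No shift beyond the scatter is expected in this assay, though the uncertainty is wide in both directions. The expected change is a 1.5-fold higher number from compound 2 to compound 3 (0.18 log units; within the scatter). Compound 3 is estimated at 1500 nM, with an expected range of 400 nM to 6000 nM.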

Compound 3, half-maximal inhibitory concentration: 3000 nM
Compound 3: middle estimate off by 2.0-fold (0.30 log units), on the low side; the measured number falls inside the stated range.
By their numbers in this assay, from the lowest: compound 2; then compounds 3 and 1 (each within the scatter of the next).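

Replacing methoxycarbonyl with 5-aminopentyl gives a 3.0-fold higher number from compound 2 to compound 3 (0.48 log units; beyond the scatter) in this assay, so the group on this saturated chain carbon does affect the number, and compound 2 now stands beyond the scatter of both other compounds. The (6-aminohexyl)amino chain in place of piperazin-1-yl on the aromatic carbon gives a 2.0-fold lower number from compound 1 to compound 3 (0.30 log units; within the scatter), so exchanging the ring for this open chain does not by itself separate the two compounds. Nothing available explains either step.

Still open, from the compounds shown here alone, is whether the ester itself matters, which a carboxylic acid or a primary amide in place of methoxycarbonyl would address. Going by these compounds, it is also open whether a shorter aminoalkyl chain, such as 2-aminoethyl, would read with compound 2 or with compound 3.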